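This account rests on a few compounds, and the source may have more. Where it says the series, first, only, none or still open, it means among the compounds named here.

The compounds share one core, shown by compound 1 (`COc1ccc(/C=C\c2cc(OC)c(OC)c(OC)c2)cc1OCc1ccc(C=O)cc1`), which gives 800 nM in a functional assay on HepG2 cells (Homo sapiens) for antiproliferative activity, read by CCK-8 assay, with a stated time of 48 h; on this read-out lower numbers stand for stronger inhibition and higher numbers for weaker inhibition. In the same test compound 3 (`COc1ccc(/C=C\c2cc(OC)c(OC)c(OC)c2)cc1OCc1ccc(CN2CCCCC2C(=O)NCCNC(=O)OC(C)(C)C)cc1`), with a much larger group on that core, gives 1100 nM. Compound 2 (`COc1ccc(/C=C\c2cc(OC)c(OC)c(OC)c2)cc1OCc1ccc(CN[C@H](C(=O)O)[C@H](C)O)cc1`) gives > 10000 nM, which is a limit of the assay and not a number; that is the limit of > 10000 nM in this assay, at which 1 of the 3 values shown sits.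

Compound 4 (`COc1ccc(/C=C\c2cc(OC)c(OC)c(OC)c2)cc1OCc1ccc(CN2CC[C@H](O)C2)cc1`) departs from compound 2 by 3-hydroxypyrrolidin-1-yl in place of (1-carboxy-2-hydroxypropyl)amino on a saturated chain carbon bound to an aromatic carbon. Within the data shown here, only one measured step bears on this change, and it is large: an at least 12-fold higher number from compound 1 to compound 2 (1.09 log units; beyond the scatter). That step brought in the group that now leaves, so a large move in the opposite direction, towards stronger inhibition in this assay, is expected. Since compound 2 has only a limit, the size stays uncertain. The expected change is an at least 6.6-fold lower number from compound 2 to compound 4 (0.82 log units; beyond the scatter). Compound 4 is estimated at 1500 nM, with an expected range of 400 nM to 6000 nM.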

Compound 4, half-maximal inhibitory concentration: 6600 nM
Estimate against measurement, compound 4: 4.4-fold (0.64 log units) below; the whole stated range lies below it.
By their numbers in this assay, from the lowest: compounds 1 and 3 (each within the scatter of the next); then compound 4. At a limit, above all of these: compound 2.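

In this assay, 3-hydroxypyrrolidin-1-yl in place of (1-carboxy-2-hydroxypropyl)amino gives an at least 1.5-fold lower number from compound 2 to compound 4 (0.18 log units; that floor lies within the scatter), so on a saturated chain carbon bound to an aromatic carbon this change can be read only as a floor, and that floor lies within the scatter. Compound 2 stands at a limit of the assay and not at a number: the limit of > 10000 nM in this assay, at which 1 of the 4 values shown sits.

Measured against formyl, the (3-hydroxypyrrolidin-1-yl)methyl group gives an 8.3-fold higher number from compound 1 to compound 4 (0.92 log units; beyond the scatter), so a group without the carboxylic acid still does not restore the formyl level.

From the compounds shown here alone, what a plain pyrrolidin-1-yl or a dimethylamino group would give at this place remains open, and so does the contribution of the hydroxyl on the ring. Going by these compounds, the true distance between the two amines in this assay also stays open.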